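The source may report more compounds than this note shows. Statements on the series, on what has been measured and on what is new or still open speak of the compounds shown alone.

Three compounds share one core. Compound 1 `C[C@]1(CN2CCc3nc(N4CCC(F)(F)CC4)ccc3C2)Cn2cc([N+](=O)[O-])nc2O1` has no result in an ADME assay on Vero cells (Chlorocebus sabaeus) for cytotoxicity, read by MTT assay, with a stated time of 72 h; a higher number here means that more compound is tolerated, a lower number that less compound is tolerated: "not determined" (no result reported). Compound 2 `C[C@]1(CN2CCc3nc(-c4cccc(F)c4)ccc3C2)Cn2cc([N+](=O)[O-])nc2O1` reaches only a limit of this assay, > 32 ug/mL. Compound 3 `C[C@]1(CN2CCc3nc(-c4cc(F)cc(F)c4)ccc3C2)Cn2cc([N+](=O)[O-])nc2O1` likewise gives a limit, > 32 ug/mL. Going by the values given here, the step that the two limits leave unreadable from compound 2 to compound 3 therefore cannot be sized, and compound 3 stands at the limit with one further limit and one entry without a number beside it, so that the limit of > 32 ug/mL in this assay, at which 2 of the 3 values shown sit, is the only evidence in hand. Compound 4 `C[C@]1(CN2CCc3nc(-c4cc(F)c(F)c(F)c4)ccc3C2)Cn2cc([N+](=O)[O-])nc2O1` differs from compound 3 by fluoro in place of hydrogen on an aromatic carbon. No readable step bears on this change, and the two limits give no reason to expect a step beyond the scatter in this assay. Compound 4 is thus expected to show again a limit, estimated at 32 ug/mL (range 20 ug/mL to 64 ug/mL), a step of a number no higher from compound 3 to compound 4 (the limit leaves the size open).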

Compound 4, half-maximal cytotoxic concentration: > 32 ug/mL
Compound 4 was reported as a limit; the forecaster's own chance of this, stated with the estimate: 80%; the middle value lies on the limit itself.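

Going by these compounds alone, the steps among compound 2, compound 3 and compound 4 cannot be read in this assay, so compound 4 adds no new step. The compounds shown leave open how much compound each actually tolerates and whether added fluoro changes that.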